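Same halophenyl swap, carried onto a sulfur-containing core

The source may report more compounds than this note shows. Statements on the series, on what has been measured and on what is new or still open speak of the compounds shown alone.

In a functional assay on HCT-116 cells (Homo sapiens) for antiproliferative activity, read by MTT assay, with a stated time of 72 h (a lower number here means a stronger inhibitor, a higher number a weaker inhibitor), the measured compounds gave the following numbers. Compound 1 `NC1=NC2(CCOCC2)N(OCCCOc2ccc(Cl)cc2)C(N)=N1`: 690 nM. Compound 2 `NC1=NC2(CCOCC2)N(OCCCOc2cccc(Br)c2)C(N)=N1`: 40 nM. Compound 3 `NC1=NC2(CCSCC2)N(OCCCOc2cccc(Br)c2)C(N)=N1`: 1 nM.

Compound 1 and compound 2 share one core and differ only in the aromatic group at the end of the chain: the change is 4-chlorophenyl in place of 3-bromophenyl on an oxygen on a saturated carbon, and it made a step of a 17-fold higher number from compound 2 to compound 1 (1.24 log units; beyond the scatter). That is a large loss of potency for a small change in where the halogen sits and which halogen it is.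

Compound 3 carries the same 3-bromophenoxy end as compound 2 but a different core; how the two cores differ is not broken down here. Among the three measured compounds, compound 3 gives the lowest number in this assay, well beyond the scatter from both compound 2 and compound 1.

Compound 4 `NC1=NC2(CCSCC2)N(OCCCOc2ccc(Cl)cc2)C(N)=N1` is compound 3 with the same swap applied: 4-chlorophenyl in place of 3-bromophenyl on an oxygen on a saturated carbon. The place of the change reads the same in both pairs, so this is the same change on the other core. For the measured compounds named here, the expected step from compound 3 to compound 4 is a 17-fold higher number from compound 3 to compound 4 (1.23 log units; beyond the scatter), which rests on the one earlier example, the step from compound 2 to compound 1 being a 17-fold higher number from compound 2 to compound 1 (1.24 log units; beyond the scatter). The expected value for compound 4 in this assay is 17 nM, with a likely range from 5 nM to 80 nM.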

Compound 4, half-maximal inhibitory concentration: 10 nM
Compound 4: middle estimate off by 1.7-fold (0.23 log units), on the high side; the measured number falls inside the stated range.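

On the sulfur-containing core, the change from 3-bromophenyl to 4-chlorophenyl again weakens the compound in this assay, with a 10-fold higher number from compound 3 to compound 4 (1.00 log units; beyond the scatter). The change therefore carries over between these two cores, with steps in the same direction and of sizes that cannot be told apart: the same change on two cores in this assay, a 17-fold higher number (1.24 log units; beyond the scatter) from compound 2 to compound 1 and a 10-fold higher number (1.00 log units; beyond the scatter) from compound 3 to compound 4, 1.7-fold (0.24 log units) apart, within the scatter of two such steps. For the compounds shown here, this rests on only two pairs in one assay, so it does not show that the step would hold on a third core, and it does not explain why the step occurs; the swap also alters both the halogen and its place on the ring, so these pairs cannot show which of the two matters.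

Going by these compounds, what remains open is how other end groups would behave on these two cores, such as a plain phenyl group or a phenyl group carrying a nitrile or a methoxy group. Also open, on these data alone, is whether the step would keep its size with a longer chain leading to the aromatic end, or with an amine in place of the oxygen that joins that chain to the aromatic ring.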